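Moving the Furan Attachment in a Growth Inhibitor Series

The source may report more compounds than this note shows. Statements on the series, on what has been measured and on what is new or still open speak of the compounds shown alone.

In a functional assay on RPTEC cells (Homo sapiens) for antiproliferative activity (a higher number here means a weaker inhibitor of growth, a lower number a stronger inhibitor of growth), compound 2 `c1ccc(-c2cc(-c3ccco3)cc(-c3ccccn3)n2)nc1` gives 0.0041 ug/mL, and compound 1 `c1ccc(-c2cc(-c3ccsc3)cc(-c3ccccn3)n2)nc1` gives 0.0047 ug/mL, so the two stand level. Compound 3 `c1ccc(-c2cc(-c3ccoc3)cc(-c3ccccn3)n2)nc1` has the same atoms as compound 2, joined differently: furan-3-yl in place of furan-2-yl on an aromatic carbon. Within the data shown here, the only measured step that bears on this is a 1.1-fold lower number from compound 1 to compound 2 (0.06 log units; within the scatter), with furan-2-yl in place of thiophen-3-yl. Among the measured compounds shown here, no measured pair isolates a change between furan-2-yl and furan-3-yl, so the comparison is indirect. The expected change is a 1.1-fold higher number from compound 2 to compound 3 (0.04 log units; within the scatter), no step beyond the scatter. For compound 3 the estimate is 0.0045 ug/mL, with an expected range from 0.0018 ug/mL to 0.011 ug/mL.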

Compound 3, concentration for 50% growth inhibition: 0.0058 ug/mL
Compound 3: middle estimate off by 1.3-fold (0.11 log units), on the low side, and the stated range covers the measured number.
By their numbers in this assay, from the lowest: compounds 2, 1 and 3 (each within the scatter of the next).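

In this assay, swapping furan-2-yl for furan-3-yl on this aromatic carbon gives a 1.4-fold higher number from compound 2 to compound 3 (0.15 log units; within the scatter), a direct reading of the furan attachment point that compounds 1 and 2 alone could not give. Replacing thiophen-3-yl with furan-3-yl gives a 1.2-fold higher number from compound 1 to compound 3 (0.09 log units; within the scatter), so all three five-membered aromatic rings stand level at this position. No evidence is available to explain this level result. Still open, as far as these compounds go, is how a larger or quite different group, such as phenyl, an amine or a carboxylic acid, would behave on this carbon.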